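Flipping One Stereocentre: From Compound 2 to Compound 4

This account rests on a few compounds, and the source may have more. Where it says the series, first, only, none or still open, it means among the compounds named here.

Of the compounds shown here, three built on one shared core have been tested in an assay on HEK293 cells for inhibition of Voltage-dependent T-type calcium channel subunit alpha-1G (Homo sapiens), read by patch clamp, tested at 10 uM; on this read-out lower numbers stand for less inhibition and higher numbers for more inhibition at the one concentration tested (going by the name of the read-out). Compound 1 `O[C@H](COc1ccc(C(F)(F)F)cc1)CN1CCN(c2ccccc2F)CC1` gives 48.9%. Compound 2 `O[C@H](COc1ccc(C(F)(F)F)cc1)CN1CCN(c2ccc(F)cc2)CC1` gives 59.2%, the highest of the three numbers. Compound 3 `O[C@H](COc1ccc(Cl)cc1)CN1CCN(c2ccc(F)cc2)CC1` gives 28.3%. Two single-change steps connect them: a number 10.3 percentage points higher from compound 1 to compound 2 (beyond the scatter), and a number 30.9 percentage points lower from compound 2 to compound 3 (beyond the scatter). Compound 2 therefore stands above both of its neighbours, beyond the scatter in each case, with compound 1 the nearer of the two and compound 3 the further.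

Compound 4 `O[C@@H](COc1ccc(C(F)(F)F)cc1)CN1CCN(c2ccc(F)cc2)CC1` is the compound still to be measured. Compared with compound 2, (the two compounds have the same atoms and bonds and differ only in configuration as drawn: 1 of 1 stereo elements differ; a stereocentre at a saturated chain carbon is drawn S in compound 2 and R in compound 4). Neither measured step bears on a change of this kind: one exchanges 2-fluorophenyl for 4-fluorophenyl, the other trifluoromethyl for chloro, and both alter which atoms are present, whereas here nothing leaves and nothing enters. The data so far give no guide to either the size or the direction of the step, so the expectation rests on compound 2 alone and is widened to reflect that. Compound 4 is expected to reach about 45%, within an estimated range of 15% to 70%. This estimate corresponds to an expected step of a number 14.2 percentage points lower from compound 2 to compound 4 (beyond the scatter), carrying broad uncertainty in both directions.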

Compound 4, a percentage reported as inhibition, at one concentration (the size of the read-out at that concentration, not a potency): 53.7%
For compound 4 the middle estimate is 8.7 percentage points below the measured one; measured number inside the range.
By their numbers in this assay, from the lowest: compound 3; then compounds 1, 4 and 2 (each within the scatter of the next, the first and the last beyond it).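

In this assay, inverting the stereocentre at the saturated chain carbon gives a number 5.5 percentage points lower from compound 2 to compound 4 (within the scatter), so at this one concentration the read-out does not separate the S and R forms of this compound. The earlier steps shown here, both beyond the scatter, each exchanged one group for another and so altered which atoms were present; this pair isolates the arrangement at a single carbon, which the earlier compounds could not do. That makes the comparison a clean test of this position, and its interpretation rests on one structural fact: the fact that compounds 2 and 4 differ only in the configuration as drawn

As far as these compounds go, whether the two configurations would stay within the scatter of each other on a different background remains open, for example with chloro, a nitrile or a carboxylic acid in place of trifluoromethyl, or with 2-fluorophenyl in place of 4-fluorophenyl. A reading at one concentration is also not a potency, so these results leave open whether compound 2 and compound 4 would still match across a full range of concentrations.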